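Swapping One Ring on Compound 1

A few compounds are considered here, and "the series" means these few. Any claim that something is new, unique, unknown or untested is made for them only; others in the source may bear on it.

In an ADME assay on MCF7 cells (Homo sapiens) for cytotoxicity, with a stated time of 72 h (on this read-out lower numbers stand for stronger inhibition and higher numbers for weaker inhibition), compound 1 `COc1ccccc1CNc1ncnc2c1ncn2C1CCCCO1` gives > 100000 nM, which is a limit of the assay and not a number. Compound 2 `COc1ccc(CNc2ncnc3c2ncn3C2CCCCO2)c(OC)c1` gives > 25000 nM, which is also a limit. Compound 3 `Oc1cc(O)cc(CNc2ncnc3c2ncn3C2CCCCO2)c1` gives > 100000 nM, again a limit. No true half-maximal concentration has therefore been read for any of these three compounds.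

The unmeasured compound 4 `COc1ccccc1CNc1ncnc2c1ncn2C1CCCO1` differs from compound 1 in one place: oxolan-2-yl in place of oxan-2-yl on an aromatic nitrogen. Oxolan-2-yl stands in place of oxan-2-yl on an aromatic nitrogen, so a six-membered non-aromatic ring gives way to a five-membered one.

Two measured steps offer some guidance. Methoxy in place of hydrogen on an aromatic carbon is a step that the two limits leave unreadable from compound 1 to compound 2. Placing 3,5-dihydroxyphenyl where 2-methoxyphenyl stood is a step that the two limits leave unreadable from compound 1 to compound 3. Neither step touches the ring that changes here, and neither has a readable size.

Compound 1 gives the limit > 100000 nM, so the expected outcome is again no readable inhibition. The estimated change, in no particular direction, is a number no higher from compound 1 to compound 4 (the limit leaves the size open). Compound 4 is estimated at 100000 nM, with an expected range from 30000 nM to 200000 nM.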

Compound 4, half-maximal inhibitory concentration: > 100000 nM
Compound 4 gave a limit, no number (the forecaster's own chance of this, stated with the estimate: 85%); the middle value lies on the limit itself.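

Compound 1 and compound 4 each give a limit of the assay and not a number, and the step between them, oxolan-2-yl in place of oxan-2-yl, cannot be read. The compounds shown leave open whether any of them has a true half-maximal concentration in this assay, and whether this ring swap changes it at all.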